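Removing a methyl from the pyridine ring: what to expect

The source may report more compounds than this note shows. Statements on the series, on what has been measured and on what is new or still open speak of the compounds shown alone.

Measured so far:
Compound 1 `N/C(=N\NC(=S)N1CCOCC1)c1ccccn1` gives 12.7% in a functional assay on HeLa cells (Homo sapiens) for cytotoxicity, read by MTT assay, with a stated time of 72 h, tested at 1 uM; a higher number here means more inhibition of growth at the concentration tested, a lower number less inhibition of growth.
Compound 2 `Cc1cccc(/C(N)=N/NC(=S)N2CCSCC2)n1` gives 46.5% in this assay.
Compound 3 `Cc1ccnc(/C(N)=N/NC(=S)N2CCSCC2)c1` gives 41.1% in this assay.

Compound 3 sits close to compound 2, the two values lying within the usual scatter of each other, while it is clearly higher than compound 1, a gap beyond the scatter. Compound 4 `N/C(=N\NC(=S)N1CCSCC1)c1ccccn1` differs from compound 3 in one place only: hydrogen in place of methyl on an aromatic carbon. For the measured compounds named here, no directly comparable pair of measured compounds shows the effect of this single change, so the expected step is uncertain. A modest drop, near the edge of the scatter, is expected from compound 3 to compound 4, a number 8.1 percentage points lower from compound 3 to compound 4 (within the scatter). Compound 4 is therefore estimated at 33%, within a range from 12% to 50%.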

Compound 4, percent growth inhibition at one concentration: 25.1%
Compound 4: the middle estimate sits 7.9 percentage points above what was measured, and the stated range covers the measured number.
By their numbers in this assay, from the lowest: compound 1; then compound 4; then compounds 3 and 2 (each within the scatter of the next).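

Hydrogen in place of methyl gives a number 16 percentage points lower from compound 3 to compound 4 (beyond the scatter) in this assay, so the methyl at this ring carbon goes with more growth inhibition than hydrogen. The same change from another aromatic carbon gives a number 21.4 percentage points lower from compound 2 to compound 4 (beyond the scatter) and points the same way, while thiomorpholin-4-yl in place of morpholin-4-yl gives a number 12.4 percentage points higher from compound 1 to compound 4 (beyond the scatter) on the ring without a methyl. Nothing available explains these steps. Still open, as far as these compounds go, is how an ethyl group, a methoxy group or a chlorine atom would compare with methyl at this ring carbon, and whether methyl has the same effect on a compound carrying morpholin-4-yl.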